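Aryl variation at the amide-bearing carbon: compound 4

This account rests on a few compounds, and the source may have more. Where it says the series, first, only, none or still open, it means among the compounds named here.

Measured so far:
- compound 1 `CCC(=O)NC(C)c1cc(Cl)c2cccnc2c1O`: > 50000 nM, a limit of the assay
- compound 2 `CCC(=O)NC(c1ccc(C)s1)c1cc(Cl)c2cccnc2c1O`: 3500 nM
- compound 3 `CCC(=O)NC(c1ccc(Br)o1)c1cc(Cl)c2cccnc2c1O`: > 75000 nM, a limit of the assay

In an assay for inhibition of Polyunsaturated fatty acid lipoxygenase ALOX12 (Homo sapiens), read by spectrophotometry (a lower number here means a stronger inhibitor, a higher number a weaker inhibitor), compound 3 sits at the limit (the limit of > 75000 nM in this assay, at which 1 of the 3 values shown sits); no number is known for it. Compound 1 sits at the other limit, (the limit of > 50000 nM in this assay, at which 1 of the 3 values shown sits). Only compound 2 gives a number, and it is the lowest of the three values.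

Compound 4 `CCC(=O)NC(c1ccc(C)cc1)c1cc(Cl)c2cccnc2c1O` differs from compound 3 by 4-methylphenyl in place of 5-bromofuran-2-yl on a saturated chain carbon bound to an amide-type nitrogen and an aromatic carbon. Among the measured compounds shown here, the steps that bear on this change are an at least 14-fold lower number from compound 1 to compound 2 (1.15 log units; beyond the scatter) and an at least 21-fold higher number from compound 2 to compound 3 (1.33 log units; beyond the scatter), both large and beyond the scatter; a step that the two limits leave unreadable from compound 1 to compound 3 is unreadable between the two limits. A five-membered aromatic ring carrying a methyl group thus gave a measurable number, whereas the bromofuran gave only a limit. A six-membered carbon-only ring carrying a methyl group is expected to move the value down, towards that of compound 2, by about an at least 15-fold lower number from compound 3 to compound 4 (1.17 log units; beyond the scatter) in this assay.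

Compound 4 is estimated at 5000 nM, within 1500 nM to 30000 nM.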

Compound 4, half-maximal inhibitory concentration: > 150000 nM
Compound 4 was reported as a limit; the forecaster's own chance of this, stated with the estimate: 15%; at least 30-fold (1.47 log units) between middle value and limit.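

In this assay compound 4 is reported only as a limit: the limit of > 150000 nM in this assay, at which 1 of the 4 values shown sits. Putting 4-methylphenyl in place of 5-methylthiophen-2-yl gives an at least 42-fold higher number from compound 2 to compound 4 (1.63 log units; beyond the scatter), so a methyl-bearing aromatic ring on the saturated chain carbon does not by itself give a measurable inhibitor, and among the compounds shown only the 5-methylthiophen-2-yl of compound 2 gives a number. The steps from compound 3 to compound 4 and from compound 1 to compound 4 join two limits and cannot be read.

The compounds shown leave open whether the number for compound 2 goes with the thiophene ring or with its methyl group, a question that 5-methylfuran-2-yl and 5-bromothiophen-2-yl on the same carbon would separate. Also open, as far as these compounds go, is whether an unsubstituted phenyl or thiophen-2-yl there gives a number in this assay.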